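The compounds below may be only part of what the source reports. "The series", "measured", "known", "first", "only" and "open" are said of these compounds alone.

Compound 1 `Cc1ccc(C(=O)Nc2cccc(NC(=O)COc3ccc4c(=O)ccoc4c3)c2)cc1` and compound 2 `O=C(COc1ccc2c(=O)ccoc2c1)Nc1cccc(NC(=O)c2ccc(F)cc2)c1` are built on one core. In an assay on isolated protein for inhibition of Rho-associated protein kinase 2 (Homo sapiens), read by scintillation counting, radiometric assay and 33P incorporation, with a stated time of 40 min, in the presence of a further agent that is not named here (on this read-out lower numbers stand for stronger inhibition and higher numbers for weaker inhibition), compound 1 gives 22 nM, and compound 2 gives 54 nM. The change between them, (fluoro in place of methyl on an aromatic carbon), made a 2.5-fold higher number from compound 1 to compound 2 (0.39 log units; beyond the scatter). Compound 3 `Cc1cc(NC(=O)COc2ccc3c(=O)ccoc3c2)cc(NC(=O)c2ccc(N(C)C)cc2)c1` yields only a limit in this assay, > 10000 nM, which is the limit of > 10000 nM in this assay, at which 1 of the 3 values shown sits. How the core of compound 3 differs from that of compound 1 is not broken down here. Compound 4 `CN(C)c1ccc(C(=O)Nc2cc(F)cc(NC(=O)COc3ccc4c(=O)ccoc4c3)c2)cc1` differs from compound 3 by fluoro in place of methyl on an aromatic carbon; as the place is not the same, this is the same kind of change, not the same. The expected step is a step that the limit leaves unreadable from compound 3 to compound 4. This rests on compound 3, whose result in this assay is a limit, > 10000 nM. It also rests on the modest step of a 2.5-fold higher number from compound 1 to compound 2 (0.39 log units; beyond the scatter). Compound 4 is therefore estimated at 20000 nM, between 7000 nM and 60000 nM.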

Compound 4, half-maximal inhibitory concentration: 22 nM
Beside the measured number, compound 4's estimate is 910-fold (2.96 log units) above it, outside the stated range (below it).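

In this assay, fluoro in place of methyl on an aromatic carbon gave an at least 450-fold lower number from compound 3 to compound 4 (2.65 log units; beyond the scatter), so the size and direction of this change did not carry from one core to the other: the same change on two cores in this assay, a 2.5-fold higher number (0.39 log units; beyond the scatter) from compound 1 to compound 2 and an at least 450-fold lower number (2.65 log units; beyond the scatter) from compound 3 to compound 4, at least 1100-fold (3.04 log units) apart, beyond the scatter of two such steps

Compound 3 gives > 10000 nM, which is a limit of the assay and not a number, so this step has no fixed size: the limit of > 10000 nM in this assay, at which 1 of the 4 values shown sits.

The two pairs show that the outcome of this change differed between these cores, but they do not show which difference between the cores matters, and the change does not stand in the same place in both pairs.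

The compounds shown leave open how chloro or methoxy would read in the place of the fluoro of compound 4, meta to two large groups. They also leave open whether the step would hold with a cyclic amine such as morpholine in place of the dimethylamino group.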